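The compounds below may be only part of what the source reports. "The series", "measured", "known", "first", "only" and "open" are said of these compounds alone.

Measured compounds:
- compound 1, `Cc1c(OCCCCOc2ccc(C(=O)O)cc2Cl)ccc(C(=O)CC2CCCC2)c1O`: in an assay on HEK293 cells for positive allosteric modulation of metabotropic glutamate receptor 3 (Rattus norvegicus), read by thallium flux, with a stated time of 2.5 min (a lower number here means that less compound is needed, a higher number that more compound is needed for the effect), compound 1 gives > 10000 nM, which is a limit of the assay and not a number
- compound 2, `Cc1c(OCCCCOc2ccc(C(=O)O)cc2Cl)ccc(C(=O)CC(C)C)c1O`: in this assay compound 2 gives 1140 nM

Within the data shown here, compound 2 holds the only number in this set; the remaining value, that of compound 1, is a limit (the limit of > 10000 nM in this assay, at which 1 of the 2 values shown sits). Among the measured compounds shown here, the one measured step, an at least 8.7-fold lower number from compound 1 to compound 2 (0.94 log units; beyond the scatter), concerns isopropyl in place of cyclopentyl on a saturated chain carbon bound to a carbonyl carbon, and it is at least modest.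

Compound 3, `Cc1c(OCCCCOc2ccc(C(=O)O)c(Cl)c2)ccc(C(=O)CC(C)C)c1O`, differs from compound 2 in another place: 4-carboxy-3-chlorophenyl in place of 4-carboxy-2-chlorophenyl on an oxygen on a saturated carbon. The same atoms are present, joined differently, so the chlorine moves within the ring that carries the carboxylic acid. For the measured compounds named here, no measured step touches this part of the molecule; the step from compound 1 to compound 2 changes the group on the other end of the shared core and says nothing about where the chlorine sits on the carboxyphenyl ring.

Going by the values given here, with no comparable step in hand, the expected outcome for compound 3 is a step of a 1.6-fold higher number from compound 2 to compound 3 (0.20 log units; within the scatter), that is, none beyond the scatter, and the estimate carries a wide range. The estimate for compound 3 in this assay is 1800 nM, between 400 nM and 9000 nM.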

Compound 3, half-maximal effective concentration: 2050 nM
Compound 3: middle estimate off by 1.1-fold (0.06 log units), on the low side; low and high end bracket the measured number.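

Moving the chlorine within the ring that carries the carboxylic acid gives the first reading at this end of the molecule: in this assay, 4-carboxy-3-chlorophenyl in place of 4-carboxy-2-chlorophenyl gives a 1.8-fold higher number from compound 2 to compound 3 (0.25 log units; within the scatter). The earlier step, an at least 8.7-fold lower number from compound 1 to compound 2 (0.94 log units; beyond the scatter), showed that the group at the other end of the shared core can shift the number beyond the scatter, whereas this change of chlorine position does not, so compound 2 and compound 3 cannot be told apart in this assay. Nothing measured here offers an explanation for this result.

The compounds shown do not tell whether the ring needs a chlorine at all, or how a fluorine or a methyl in its place, or a tetrazole in place of the carboxylic acid, would read in this assay. They also leave open how a longer chain linking the two oxygens would read, and whether the two chlorine positions would remain indistinguishable alongside a group other than isopropyl on the saturated chain carbon bound to the carbonyl carbon.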